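Oligoether esters of the shared core: solubility notes

This account rests on a few compounds, and the source may have more. Where it says the series, first, only, none or still open, it means among the compounds named here.

Compound 1 `COCCOCCOCCOCCOCC(=O)Oc1c(C(C)C)cccc1C(C)C` and compound 2 `COCCOCCOCCOCCOCCOCCOCC(=O)Oc1c(C(C)C)cccc1C(C)C` share one core and differ only in the length of the oligoether chain on the ester. In a physicochemical assay for solubility, in phosphate buffer, at pH 7.4 (a lower number here means a less soluble compound, a higher number a more soluble compound), compound 1 gives 1580 ug/mL, and compound 2 gives 2020 ug/mL. For the measured compounds named here, the one step between them, a 1.3-fold higher number from compound 1 to compound 2 (0.11 log units; within the scatter), is the only measured step. Compound 2 holds the highest of the two numbers, but its distance to compound 1 is within the scatter, so no order between them is claimed.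

Compound 3 `COCCOCCOCCOCCOCCOCCOCCOCC(=O)Oc1c(C(C)C)cccc1C(C)C` is the next member, with methoxymethyl in place of hydrogen on a saturated chain carbon bound to an oxygen on a saturated carbon. The step that bears on this change is a 1.3-fold higher number from compound 1 to compound 2 (0.11 log units; within the scatter), which added a longer piece of the same chain and stayed within the scatter; for the shorter addition to compound 3 a step of similar size or none beyond the scatter is therefore expected in this assay, as a 1.1-fold higher number from compound 2 to compound 3 (0.04 log units; within the scatter). Compound 3 is estimated at 2200 ug/mL, with a range from 1200 ug/mL to 3800 ug/mL.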

Compound 3, solubility: > 216000 ug/mL
Compound 3 ended at the assay's limit; the forecaster's own chance of this, stated with the estimate: 5%; middle value at least 98-fold (1.99 log units) away from the limit.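

Notes on the chain position: In this assay, extension at the saturated chain carbon bound to an oxygen on a saturated carbon is now shown to be capable of a large step, which the earlier pair did not show, with a 1.3-fold higher number from compound 1 to compound 2 (0.11 log units; within the scatter) against an at least 100-fold higher number from compound 2 to compound 3 (2.02 log units; beyond the scatter). Measured across the whole extension, with (2-(2-methoxyethoxy)ethoxy)methyl in place of hydrogen, the result is an at least 130-fold higher number from compound 1 to compound 3 (2.13 log units; beyond the scatter). For compound 3 the number is a limit of the assay and not a measured value: the limit of > 216000 ug/mL in this assay, at which 1 of the 3 values shown sits.

Where the true value of compound 3 lies, and so the full size of both steps, stays open. As far as these compounds go, it is also open whether a longer chain, or a chain ending in an amine or a carboxylic acid, would give a step of this kind.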